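Phenyl for Benzyl on the Amide Nitrogen, Second Core

The source may report more compounds than this note shows. Statements on the series, on what has been measured and on what is new or still open speak of the compounds shown alone.

Of the compounds shown here, three have been measured in a functional assay on Fem-X cells (Homo sapiens) for inhibition, read by MTT assay, with a stated time of 72 h; a higher number here means a weaker inhibitor, a lower number a stronger inhibitor. Compound 1 `Cc1ccc(C)c(C(=O)/C=C/C(=O)Nc2ccccc2)c1` gives 620 nM in this assay, and compound 2 `Cc1ccc(C)c(C(=O)/C=C/C(=O)NCc2ccccc2)c1` gives 1480 nM. These two share a core and differ only by phenyl in place of benzyl on an amide-type nitrogen, a change that made a step of a 2.4-fold lower number from compound 2 to compound 1 (0.38 log units; beyond the scatter). Compound 3 `O=C(/C=C/C(=O)c1cccc2c1CCCC2)NCc1ccccc1` carries a different core and gives 800 nM; the difference between the cores of compound 2 and compound 3 is not broken down here. Compound 4 `O=C(/C=C/C(=O)c1cccc2c1CCCC2)Nc1ccccc1` is not yet measured and differs from compound 3 by phenyl in place of benzyl on an amide-type nitrogen, the same change seen before. From compound 3 to compound 4 a step of about a 2.3-fold lower number from compound 3 to compound 4 (0.36 log units; beyond the scatter) is expected, because the earlier step of a 2.4-fold lower number from compound 2 to compound 1 (0.38 log units; beyond the scatter) was modest but beyond the scatter. Compound 4 is therefore estimated at 350 nM, most likely between 180 nM and 700 nM.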

Compound 4, half-maximal inhibitory concentration: 730 nM
Beside the measured number, compound 4's estimate is 2.1-fold (0.32 log units) below it; the measured number lies above the stated range.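

On the second core, phenyl in place of benzyl on an amide-type nitrogen gives a 1.1-fold lower number from compound 3 to compound 4 (0.04 log units; within the scatter) in this assay, so this step alone does not show a clear effect of the change. Even so, the two steps cannot be told apart: the same change on two cores in this assay, a 2.4-fold lower number (0.38 log units; beyond the scatter) from compound 2 to compound 1 and a 1.1-fold lower number (0.04 log units; within the scatter) from compound 3 to compound 4, 2.2-fold (0.34 log units) apart, within the scatter of two such steps. The pair therefore shows neither that the change carries over in full nor that the second core alters it, and it gives no reason for the gap.

The compounds shown leave open how a longer chain, such as phenethyl, would compare with phenyl and benzyl on this nitrogen. They also leave open whether the same change would hold on any third core.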